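This account rests on a few compounds, and the source may have more. Where it says the series, first, only, none or still open, it means among the compounds named here.

Compound 2 `Cc1ccc(C)c(NC(=O)c2ccc(/N=N\c3c[nH]c4ccccc34)cc2)c1` gives 29900 nM in a functional assay on MCF7 cells (Homo sapiens) for inhibition, read by MTT assay, with a stated time of 72 h (a higher number here means a weaker inhibitor, a lower number a stronger inhibitor), the lower of the two numbers in hand, while compound 1 `Cc1cccc(NC(=O)c2ccc(/N=N\c3c[nH]c4ccccc34)cc2)c1C` gives 106000 nM in this assay, separated by the step of a 3.5-fold lower number from compound 1 to compound 2 (0.55 log units; beyond the scatter). Compound 3 `O=C(Nc1ccccc1F)c1ccc(/N=N\c2c[nH]c3ccccc23)cc1` carries 2-fluorophenyl in place of 2,5-dimethylphenyl on an amide-type nitrogen. For the measured compounds named here, the only measured step moved two methyl groups about the same ring and bears loosely on exchanging both for one fluorine, so it offers no clear direction. The expected step of a 1.7-fold higher number from compound 2 to compound 3 (0.22 log units; within the scatter) is therefore small and may not exceed the scatter. Compound 3 is estimated at 50000 nM in this assay, within 15000 nM to 160000 nM.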

Compound 3, half-maximal inhibitory concentration: 83800 nM
Estimate against measurement, compound 3: 1.7-fold (0.22 log units) below; the measured number falls inside the stated range.
By their numbers in this assay, from the lowest: compound 2; then compounds 3 and 1 (each within the scatter of the next).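

In this assay the step of a 2.8-fold higher number from compound 2 to compound 3 (0.45 log units; beyond the scatter) shows that the amide-type nitrogen's aryl group matters beyond a shift of methyl groups, since 2-fluorophenyl gives up part of the gain held by 2,5-dimethylphenyl. The step of a 1.3-fold lower number from compound 1 to compound 3 (0.10 log units; within the scatter) leaves 2-fluorophenyl and 2,3-dimethylphenyl unseparated. Nothing available explains either step. The compounds shown leave open how a methoxy group or an amine on this ring would compare, and whether a 2,5-difluorophenyl would keep the lower number of compound 2.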